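Nitro to Nitrile Swap on a Shared Core

This account rests on a few compounds, and the source may have more. Where it says the series, first, only, none or still open, it means among the compounds named here.

Compound 1 `O=C1/C(=C/c2cccc([N+](=O)[O-])c2)CN(S(=O)(=O)c2ccc(F)cc2)C/C1=C\c1ccccc1F`, compound 2 `N#Cc1ccc(/C=C2\CN(S(=O)(=O)c3ccc(F)cc3)C/C(=C\c3ccccc3F)C2=O)cc1` and compound 3 `CC(=O)Nc1ccc(S(=O)(=O)N2C/C(=C\c3cccc([N+](=O)[O-])c3)C(=O)/C(=C/c3ccccc3F)C2)cc1` were tested in a functional assay on SMMC-7721 cells (Homo sapiens) for cytotoxicity, read by MTT assay, with a stated time of 24 h; on this read-out higher numbers stand for weaker inhibition and lower numbers for stronger inhibition. In this assay compound 1 gives 7820 nM, compound 2 gives 10300 nM and compound 3 gives 10200 nM. The change 4-cyanophenyl in place of 3-nitrophenyl on a double-bonded chain carbon bound to a double-bonded ring carbon brought a 1.3-fold higher number from compound 1 to compound 2 (0.12 log units; within the scatter). Compound 3 has a different core than compound 1, the difference being (acetamido in place of fluoro on an aromatic carbon), which brought a 1.3-fold higher number from compound 1 to compound 3 (0.12 log units; within the scatter). Compound 4 `CC(=O)Nc1ccc(S(=O)(=O)N2C/C(=C\c3ccc(C#N)cc3)C(=O)/C(=C/c3ccccc3F)C2)cc1` is not yet measured. It differs from compound 3 by 4-cyanophenyl in place of 3-nitrophenyl on a double-bonded chain carbon bound to a double-bonded ring carbon, the same change, at the same place, that turns compound 1 into compound 2. Because that change gave a 1.3-fold higher number from compound 1 to compound 2 (0.12 log units; within the scatter), a step of about the same size is expected here. The expected step is a 1.3-fold higher number from compound 3 to compound 4 (0.11 log units; within the scatter). Compound 4 is therefore estimated at 13000 nM, probably between 6500 nM and 26000 nM.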

Compound 4, half-maximal inhibitory concentration: 3150 nM
For compound 4 the middle estimate is 4.1-fold (0.62 log units) above the measured one, and the stated range ends above it.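

On the acetamido-bearing core, 4-cyanophenyl in place of 3-nitrophenyl brings a 3.2-fold lower number from compound 3 to compound 4 (0.51 log units; beyond the scatter), and on the 4-cyanophenyl-bearing core, acetamido in place of fluoro brings a 3.3-fold lower number from compound 2 to compound 4 (0.51 log units; beyond the scatter). The step from 3-nitrophenyl to 4-cyanophenyl therefore does not keep its size from one core to the other: the same change on two cores in this assay, a 1.3-fold higher number (0.12 log units; within the scatter) from compound 1 to compound 2 and a 3.2-fold lower number (0.51 log units; beyond the scatter) from compound 3 to compound 4, 4.3-fold (0.63 log units) apart, beyond the scatter of two such steps. The step from fluoro to acetamido likewise depends on the group present elsewhere in the molecule, although four compounds give neither a reason for this nor a rule for other cores: the same change on two cores in this assay, a 1.3-fold higher number (0.12 log units; within the scatter) from compound 1 to compound 3 and a 3.3-fold lower number (0.51 log units; beyond the scatter) from compound 2 to compound 4, 4.3-fold (0.63 log units) apart, beyond the scatter of two such steps.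

From the compounds shown here alone, whether an amine or a carboxylic acid in place of the acetamido group would show the same dependence remains open. So does whether the lower number of compound 4 would hold with a longer chain in that place.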